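Methylsulfanyl analogue of compound 3: expected growth inhibition

The source may report more compounds than this note shows. Statements on the series, on what has been measured and on what is new or still open speak of the compounds shown alone.

Measured in a functional assay on MCF7 cells (Homo sapiens) for cytotoxicity, read by MTT assay, with a stated time of 72 h; on this read-out lower numbers stand for stronger inhibition of growth and higher numbers for weaker inhibition of growth:
compound 1 `CCCCC[Se]c1nc(NCc2ccccc2)c2ccccc2n1` gives 50 nM
compound 2 `CSc1nc(NCc2ccc([Se]C)cc2)c2ccccc2n1` gives 36400 nM
compound 3 `CSc1nc(NCc2ccccc2)c2ccccc2n1` gives 41500 nM

Compound 3 sits at the high end of the three numbers, alongside compound 2: a 1.1-fold higher number from compound 2 to compound 3 (0.06 log units; within the scatter). Going by the values given here, the only large step in the set, an 830-fold higher number from compound 1 to compound 3 (2.92 log units; beyond the scatter), concerns the other side of the core. Compound 4 `CSc1ccc(CNc2nc(SC)nc3ccccc23)cc1` is compound 3 with methylsulfanyl in place of hydrogen on an aromatic carbon. Among the compounds with values here, the step that bears on this change is the one between compound 2 and compound 3, where a selenium-bearing group at the same place made no difference beyond the scatter. A sulfur-bearing group of the same size is therefore expected to behave alike in this assay, and the expected step is a 1.0-fold lower number from compound 3 to compound 4 (0.02 log units; within the scatter). Compound 4 is estimated at 40000 nM, range 15000 nM to 100000 nM.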

Compound 4, concentration for 50% growth inhibition: 47300 nM
For compound 4 the middle estimate is 1.2-fold (0.07 log units) below the measured one; the measured number falls inside the stated range.
By their numbers in this assay, from the lowest: compound 1; then compounds 2, 3 and 4 (each within the scatter of the next).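

Methylsulfanyl on an aromatic carbon, para to a large group, produces no step beyond the scatter: a 1.1-fold higher number from compound 3 to compound 4 (0.06 log units; within the scatter). Exchanging the selenium-bearing group for the sulfur-bearing one at this place also stays within the scatter: a 1.3-fold higher number from compound 2 to compound 4 (0.11 log units; within the scatter). No evidence is available that accounts for this flat reading.

Still open, as far as these compounds go, is whether this place stays as flat with the longer selenium-bearing chain of compound 1 on the shared core. Also open, from the compounds shown here alone, is how an amine or a carboxylic acid would read here.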